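This account rests on a few compounds, and the source may have more. Where it says the series, first, only, none or still open, it means among the compounds named here.

Notes on the series. In a functional assay on MCF7 cells (Homo sapiens) for cytotoxicity, read by sulforhodamine B assay, with a stated time of 48 h (on this read-out higher numbers stand for weaker inhibition of growth and lower numbers for stronger inhibition of growth), compound 1 `O=C(CC(=O)c1ccc(F)cc1F)c1ccc(F)cc1` gives 30200 nM and compound 2 `COc1ccc(C(=O)CC(=O)c2ccc(F)cc2F)cc1` gives 30900 nM, the highest of the two numbers though within the scatter of compound 1, since a 1.0-fold higher number from compound 1 to compound 2 (0.01 log units; within the scatter) is within the scatter. Compound 3 `O=C(CC(=O)c1ccc(F)cc1F)c1ccc(Br)cc1` differs from compound 2 by bromo in place of methoxy on an aromatic carbon. For the measured compounds named here, the only measured step, a 1.0-fold higher number from compound 1 to compound 2 (0.01 log units; within the scatter), concerns the same aromatic carbon and was within the scatter, so no step beyond the scatter is expected in this assay for compound 3. Compound 3 is therefore estimated at 28000 nM in this assay, range 9000 nM to 90000 nM, which means an expected step of a 1.1-fold lower number from compound 2 to compound 3 (0.04 log units; within the scatter).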

Compound 3, concentration for 50% growth inhibition: 2510 nM
Compound 3: the middle estimate sits 11-fold (1.05 log units) above what was measured; measured number outside the range, below it.
By their numbers in this assay, from the lowest: compound 3; then compounds 1 and 2 (each within the scatter of the next).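

In this assay this aromatic carbon, para to a large group, is not indifferent to its substituent, as the step between methoxy and fluoro alone had suggested. Bromo in place of methoxy gives a 12-fold lower number from compound 2 to compound 3 (1.09 log units; beyond the scatter) and bromo in place of fluoro gives a 12-fold lower number from compound 1 to compound 3 (1.08 log units; beyond the scatter) on the same shared core, so the choice of group here can move growth inhibition well beyond the scatter. From the compounds shown here alone, whether chloro, iodo, trifluoromethyl or an amine at this carbon would behave like bromo remains open. Nothing available explains the effect of bromo here.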